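Trading benzyloxy for trifluoromethyl on compound 3

The compounds below may be only part of what the source reports. "The series", "measured", "known", "first", "only" and "open" are said of these compounds alone.

Of the compounds shown here, three have been measured so far in a functional assay for inhibition, with Homo sapiens as the target; on this read-out lower numbers stand for stronger inhibition and higher numbers for weaker inhibition. Compound 1 `COc1cc(OC)c(C(=O)/C=C/c2ccc(Cl)cc2)c(OC)c1` gives 970 nM, and compound 2 `COc1cc(OC)c(C(=O)/C=C/c2ccncc2)c(OC)c1` gives 592 nM. Between these two lies a 1.6-fold lower number from compound 1 to compound 2 (0.21 log units; within the scatter), so they cannot be told apart. Compound 3 `O=C(/C=C/c1ccccc1)c1ccccc1OCc1ccccc1` gives 2230 nM, the highest of the three numbers and clearly above both others.

The next compound, compound 4 `O=C(/C=C/c1ccccc1)c1ccccc1C(F)(F)F`, has not yet been measured. It differs from compound 3 in one place: trifluoromethyl in place of benzyloxy on an aromatic carbon. Put simply, trifluoromethyl stands in place of benzyloxy on an aromatic carbon, ortho to a large group.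

Among the measured compounds shown here, only one measured step could offer guidance, namely a 1.6-fold lower number from compound 1 to compound 2 (0.21 log units; within the scatter). It is a poor guide: it involves other groups at another place, and it stays within the scatter. For the measured compounds named here, no measured compound carries trifluoromethyl, and no measured pair shows what replacing benzyloxy does. The data therefore point in neither direction, and the starting expectation in this assay is no real change.

The expected move is a 1.1-fold lower number from compound 3 to compound 4 (0.05 log units; within the scatter), a change too small to count as a true difference. The estimated value for compound 4 is 2000 nM, with an expected range from 650 nM to 6000 nM. Going by the values given here, that range is kept wide, since the change is large and has no measured precedent.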

Compound 4, half-maximal inhibitory concentration: 748 nM
Estimate against measurement, compound 4: 2.7-fold (0.43 log units) above; the range from low to high includes it.
By their numbers in this assay, from the lowest: compounds 2, 4 and 1 (each within the scatter of the next); then compound 3.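

Moving from benzyloxy to trifluoromethyl on this aromatic carbon shifts the read-out in this assay, giving a 3.0-fold lower number from compound 3 to compound 4 (0.47 log units; beyond the scatter). Among the compounds shown here, this is the first step between closely related compounds here to lie beyond the scatter, unlike a 1.6-fold lower number from compound 1 to compound 2 (0.21 log units; within the scatter), so this place on the molecule can make a measurable difference. Inhibition also does not depend on keeping benzyloxy here, since trifluoromethyl, with fewer heavy atoms and no ring, goes with the lower number, but no measurement shown here accounts for the step, which stands as an observation only.

Going by these compounds, with just two groups compared at this place, it remains open whether the step follows from losing the ring of benzyloxy, its oxygen or its overall size, and a methoxy group, a fluorine atom or a plain hydrogen in the same spot would help separate these possibilities. For the compounds shown here, it is also open whether the same exchange would give a similar step on a different core, such as the one shared by compound 1 and compound 2.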